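The compounds below may be only part of what the source reports. "The series", "measured", "known", "first", "only" and "open" are said of these compounds alone.

In a functional assay on MKN-74 cells (Homo sapiens) for antiproliferative activity, with a stated time of 24 h (a higher number here means a weaker inhibitor, a lower number a stronger inhibitor), compound 3 `NC(=O)c1c(NC(=O)c2ccccc2Cl)sc2c1CCN(Cc1ccccc1F)C2` gives 12900 nM, the higher of the two finished numbers. Compound 2 `NC(=O)c1c(NC(=O)c2ccccc2Cl)sc2c1CCN(Cc1ccccc1Cl)C2` gives 4430 nM, and the step of a 2.9-fold higher number from compound 2 to compound 3 (0.46 log units; beyond the scatter). Compound 1 `Cc1ccccc1CN1CCc2c(sc(NC(=O)c3ccccc3Cl)c2C(N)=O)C1` reaches only the limit of the assay, > 50000 nM (the limit of > 50000 nM in this assay, at which 1 of the 3 values shown sits). The steps of an at least 11-fold lower number from compound 1 to compound 2 (1.05 log units; beyond the scatter) and an at least 3.8-fold lower number from compound 1 to compound 3 (0.58 log units; beyond the scatter) show that the group on this aromatic carbon shifts the number strongly. Compound 4 `NC(=O)c1c(NC(=O)c2ccccc2Cl)sc2c1CCN(Cc1ccc([N+](=O)[O-])cc1)C2` alters the same part of the molecule: 4-nitrophenyl in place of 2-fluorophenyl on a saturated chain carbon bound to an amine nitrogen in a ring. For the measured compounds named here, no measured step covers a nitro group, so the direction is open; a modest shift in either direction is what is expected, giving an anticipated step of a 1.3-fold lower number from compound 3 to compound 4 (0.11 log units; within the scatter). Compound 4 is therefore estimated at 10000 nM, with a range from 3000 nM to 40000 nM.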

Compound 4, half-maximal inhibitory concentration: 31500 nM
For compound 4 the middle estimate is 3.2-fold (0.50 log units) below the measured one; measured number inside the range.
By their numbers in this assay, from the lowest: compound 2; then compound 3; then compound 4. At a limit, above all of these: compound 1.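

Putting 4-nitrophenyl on this saturated chain carbon still gives a finished number, but a weaker one: a 2.4-fold higher number from compound 3 to compound 4 (0.39 log units; beyond the scatter), and a 7.1-fold higher number from compound 2 to compound 4 (0.85 log units; beyond the scatter). Among the finished numbers, the nitro group therefore brings no gain over 2-fluorophenyl or 2-chlorophenyl. Compound 1 stays a limit at > 50000 nM. Against that limit there is only a floor: an at least 1.5-fold lower number from compound 1 to compound 4 (0.20 log units; that floor lies within the scatter).

The compounds shown leave open whether the rise follows the nitro group itself or its place on the ring. They also leave open how 4-chlorophenyl or a phenyl ring bearing an amine would compare.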